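The source may hold more compounds than are shown below. What is called first, only, known or untested is meant among the compounds shown, and "the series" means these compounds.

Compound 1 `Nc1nc(N)c2c(-c3ccsc3)cn([C@@H]3O[C@H](CO)[C@@H](O)[C@H]3O)c2n1`, compound 2 `Nc1nc(N)c2c(-c3ccoc3)cn([C@@H]3O[C@H](CO)[C@@H](O)[C@H]3O)c2n1` and compound 3 `Nc1nc(N)c2c(-c3ccco3)cn([C@@H]3O[C@H](CO)[C@@H](O)[C@H]3O)c2n1` differ from one another only in the group attached to an aromatic carbon of the shared core. In a functional assay on HCT-116 cells (Homo sapiens), read by MTT assay, with a stated time of 72 h (a higher number here means a weaker inhibitor, a lower number a stronger inhibitor), compound 1 gives > 20000 nM, which is a limit of the assay and not a number. Compound 2 gives > 20000 nM in this assay, again a limit. Compound 3 gives > 20000 nM, also a limit. The steps a step that the two limits leave unreadable from compound 1 to compound 2, a step that the two limits leave unreadable from compound 1 to compound 3 and a step that the two limits leave unreadable from compound 2 to compound 3 cannot be read in size because of the limit of > 20000 nM in this assay, at which 3 of the 3 values shown sit. Compound 3 therefore stands at the limit, as do the two other values shown, with no number to place it more closely.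

Compound 4 `COc1nc(N)nc2c1c(-c1ccco1)cn2[C@@H]1O[C@H](CO)[C@@H](O)[C@H]1O` is not yet measured. It differs from compound 3 in this way: methoxy in place of amino on an aromatic carbon. For the measured compounds named here, none of the measured steps touches this group; all three concern the other aromatic substituent and are unreadable in any case. Going by the values given here, there is thus no measured step that bears on the exchange of amino for methoxy, and no evidence speaks to what the methoxy group does here. Since compound 3 shows only a limit, the step that the limit leaves unreadable from compound 3 to compound 4 is expected to remain unreadable as well. Compound 4 is estimated at 30000 nM, with a range from 8000 nM to 100000 nM, and is expected most likely to be reported again only as a limit.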

Compound 4, half-maximal inhibitory concentration: > 20000 nM
Compound 4 was reported as a limit; the forecaster's own chance of this, stated with the estimate: 85%; the middle value lies beyond the limit too.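

Compound 3 and compound 4 both stand at a limit in this assay, so the exchange of amino for methoxy between them cannot be read in size: the limit of > 20000 nM in this assay, at which 4 of the 4 values shown sit.

The compounds shown leave open whether any of them has a measurable effect in this assay, and what methoxy in place of amino does to it.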